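Ethyl Carbamate Selenocyanate Expected to Track Its Allyl Parent

A few compounds are considered here, and "the series" means these few. Any claim that something is new, unique, unknown or untested is made for them only; others in the source may bear on it.

Measured compounds:
compound 1, `C=CCOC(=O)Nc1ccc([Se]C#N)cc1`, 47400 nM
compound 2, `O=C(Nc1ccc([Se][Se]c2ccc(NC(=O)OCc3ccc([N+](=O)[O-])cc3)cc2)cc1)OCc1ccc([N+](=O)[O-])cc1`, 22500 nM

In an ADME assay on BEAS-2B cells (Homo sapiens) for cytotoxicity, read by MTT assay, with a stated time of 72 h (a lower number here means a stronger inhibitor of growth, a higher number a weaker inhibitor of growth), compound 1 gives 47400 nM, the highest of the two numbers. Its nearest neighbour, compound 2, gives 22500 nM in this assay, a gap that lies beyond the usual scatter. Compound 3, `CCOC(=O)Nc1ccc([Se]C#N)cc1`, differs from compound 1 by methyl in place of vinyl on a saturated chain carbon bound to an oxygen next to a carbonyl group. Within the data shown here, no measured pair shows this change, so nothing anchors its effect. The step of a 1.1-fold lower number from compound 1 to compound 3 (0.02 log units; within the scatter) is expected to stay within the scatter, in either direction. Compound 3 is therefore estimated at 45000 nM, with a range from 20000 nM to 100000 nM.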

Compound 3, concentration for total growth inhibition: 46900 nM
Compound 3: the middle estimate sits 1.0-fold (0.02 log units) below what was measured; the range from low to high includes it.
By their numbers in this assay, from the lowest: compound 2; then compounds 3 and 1 (each within the scatter of the next).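

In this assay, among these compounds, the first measured pair at this position gives a 1.0-fold lower number from compound 1 to compound 3 (0.00 log units; within the scatter) for methyl in place of vinyl on a saturated chain carbon bound to an oxygen next to a carbonyl group. Allyl and ethyl therefore cannot be told apart in this read-out, and the double bond outside aromatic rings in the allyl chain is not required for the number seen with compound 1. No available finding bears on this result. On these data alone, whether a longer chain or an amine in place of the allyl would also leave the number within the scatter stays open.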